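Aryl variation on the shared core: readings at the assay limit

This account rests on a few compounds, and the source may have more. Where it says the series, first, only, none or still open, it means among the compounds named here.

Measured compounds:
- Compound 1, `OC[C@H]1O[C@@H](n2cnc3c(NCc4ccccc4Br)ncnc32)[C@H](O)[C@@H]1O`. In a functional assay on HOS cells (Homo sapiens) for antiproliferative activity, with a stated time of 72 h (a lower number here means a stronger inhibitor, a higher number a weaker inhibitor), compound 1 gives > 166000 nM, a limit of the assay rather than a number.
- Compound 2, `Cc1cccc(CNc2ncnc3c2ncn3[C@@H]2O[C@H](CO)[C@@H](O)[C@H]2O)c1`. In this assay compound 2 gives > 166000 nM, likewise a limit.

Within the data shown here, compound 1 therefore stands nowhere on a scale: both readings so far sit at the limit of > 166000 nM in this assay, at which 2 of the 2 values shown sit, and the one step between measured compounds, a step that the two limits leave unreadable from compound 1 to compound 2, cannot be read. Among the measured compounds shown here, no measured step bears readably on the change to compound 3, `OC[C@H]1O[C@@H](n2cnc3c(NCc4ccc(F)cc4Cl)ncnc32)[C@H](O)[C@@H]1O`, which differs from compound 1 as 2-chloro-4-fluorophenyl in place of 2-bromophenyl on a saturated chain carbon bound to a nitrogen on an aromatic ring. With nothing to read from, the expectation for compound 3 is another reading at the limit, and the step that the limit leaves unreadable from compound 1 to compound 3 is expected to be none beyond the scatter. Compound 3 is accordingly estimated at 200000 nM, within 50000 nM to 800000 nM, most likely reported only as a limit.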

Compound 3, half-maximal inhibitory concentration: > 166000 nM
Compound 3: only a limit was reported (the forecaster's own chance of this, stated with the estimate: 80%); the middle value is on the limit's open side.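

Among these compounds, compound 3 gives > 166000 nM in this assay, which is again a limit, so no step among compound 1, compound 2 and compound 3 can be read: the limit of > 166000 nM in this assay, at which 3 of the 3 values shown sit.

The compounds shown leave open whether any aryl group on the shared core gives a measurable reading in this assay.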